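The source may hold more compounds than are shown below. What is called first, only, known or untested is meant among the compounds shown, and "the series" means these compounds.

Compound 1 `CC/C=C/C(=O)Nc1cccc(Oc2nc(Nc3cccc(OC)c3)nc3ccsc23)c1`: in a functional assay on A-431 cells (Homo sapiens) for inhibition, read by MTT assay, with a stated time of 72 h (on this read-out higher numbers stand for weaker inhibition and lower numbers for stronger inhibition), compound 1 gives 29200 nM.
Compound 2 `COc1ccc(Nc2nc(Oc3cccc(NC(=O)C=C(C)C)c3)c3sccc3n2)cn1`: compound 2 gives > 50000 nM, a limit of this assay.
Compound 3 `COc1ccc(Nc2nc(Oc3cccc(NC(=O)/C=C/C(C)C)c3)c3sccc3n2)cn1`: compound 3 gives > 50000 nM, also a limit.

Compound 3 therefore stands at the edge of what this assay reports; the change a step that the two limits leave unreadable from compound 2 to compound 3 is unreadable, as the limit of > 50000 nM in this assay, at which 2 of the 3 values shown sit, shows. Compound 4 `CC(C)/C=C/C(=O)Nc1cccc(Oc2nc(Nc3cccc(C#N)c3)nc3ccsc23)c1` differs from compound 3 by 3-cyanophenyl in place of 6-methoxypyridin-3-yl on a nitrogen on an aromatic ring. Going by the values given here, no measured step bears on this change. Among the compounds with values here, compound 1 is the only member giving a number rather than a limit, and it is not a single-place neighbour of compound 3. Compound 4 is accordingly expected in the weak range, around 30000 nM (8000 nM to 60000 nM). The implied shift, an at least 1.6-fold lower number from compound 3 to compound 4 (0.22 log units; that floor lies within the scatter), is an estimate only and may again end at a limit.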

Compound 4, half-maximal inhibitory concentration: 24100 nM
Compound 4: the middle estimate sits 1.2-fold (0.10 log units) above what was measured, within the range that was stated.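

In this assay compound 3 gives > 50000 nM, a limit. With 3-cyanophenyl in place of 6-methoxypyridin-3-yl on this nitrogen, the series gains its first readable step at this position, an at least 2.0-fold lower number from compound 3 to compound 4 (0.31 log units; beyond the scatter). That size is only a floor: the limit of > 50000 nM in this assay, at which 2 of the 4 values shown sit.

The step from compound 2 to compound 3 cannot be read, so the two groups on the carbonyl carbon remain unranked. Also open, as far as these compounds go, is how an aminophenyl or carboxyphenyl group on this nitrogen would read, and whether the 3-cyanophenyl step holds with a longer chain on the carbonyl carbon.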